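A Methyl in Place of Fluoro at the Assay Limit

The source may hold more compounds than are shown below. What is called first, only, known or untested is meant among the compounds shown, and "the series" means these compounds.

In a functional assay on MOLT-4 cells (Homo sapiens) for antiproliferative activity, read by cell counting, with a stated time of 2 days (on this read-out higher numbers stand for weaker inhibition and lower numbers for stronger inhibition), compound 1 (`Nc1nc(Nc2ccc(Cl)cc2)sc1C(=O)c1ccccc1`) gives > 10000 nM as a limit and not a number. Compound 2 (`Nc1nc(Nc2ccc(F)cc2)sc1C(=O)c1ccccc1`) gives > 10000 nM in this assay as a limit too, so its standing rests on that limit alone. Among the measured compounds shown here, the only measured step is a step that the two limits leave unreadable from compound 1 to compound 2 and offers no size to carry forward. The evidence amounts to the limit of > 10000 nM in this assay, at which 2 of the 2 values shown sit, and nothing more. Compound 3 (`Cc1ccc(Nc2nc(N)c(C(=O)c3ccccc3)s2)cc1`) carries methyl in place of fluoro on an aromatic carbon and otherwise matches compound 2. Nothing measured points to a gain, so no step beyond the scatter is expected in this assay and another limit is the likeliest result. The expected step is a step that the limit leaves unreadable from compound 2 to compound 3 and remains an estimate. For compound 3 the estimated value is 15000 nM with an expected range of 6000 nM to 40000 nM in this estimate.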

Compound 3, half-maximal inhibitory concentration: 210 nM
Compound 3: middle estimate off by 71-fold (1.85 log units), on the high side; measured number below the stated range.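

In this assay, this position on an aromatic carbon para to a large group turns out to matter: the change to 4-methylphenyl gives an at least 47-fold lower number from compound 2 to compound 3 (1.67 log units; beyond the scatter), and methyl in place of chloro at the same place gives an at least 47-fold lower number from compound 1 to compound 3 (1.67 log units; beyond the scatter). Compound 1 and compound 2 could not show this, and the step between them cannot be read. So the position is not indifferent to what it carries, and the shared core can give measurable inhibition in this assay, while the two halogen compounds remain at the assay limit: the limit of > 10000 nM in this assay, at which 2 of the 3 values shown sit.

From the compounds shown here alone, the true size of both steps stays open, and so does any order between the two halogens. The compounds shown also leave open whether methyl is special here, or whether an ethyl, a methoxy or an amine at this place would do as well.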